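The source may hold more compounds than are shown below. What is called first, only, known or untested is meant among the compounds shown, and "the series" means these compounds.

Compound 1, with the structure `CCC1=C(O)c2c(oc(-c3ccc(Br)cc3)cc2=O)C(CC)(CC)C1=O`, carries a 4-bromophenyl group on the shared core. In a functional assay on KB cells (Homo sapiens) for antiproliferative activity, read by sulforhodamine B assay, with a stated time of 3 days (on this read-out higher numbers stand for an effect only at larger amounts of compound and lower numbers for an effect already at smaller amounts), compound 1 reaches only the limit of the assay, > 48.1 uM, which means no number could be read for it. Compound 2, `CCC1=C(O)c2c(oc(-c3ccc(C)cc3C)cc2=O)C(CC)(CC)C1=O`, differs from compound 1 by a 2,4-dimethylphenyl group, and in this assay compound 2 gives 41.2 uM. Among the compounds with values here, the step of an at least 1.1-fold lower number from compound 1 to compound 2 (0.06 log units; that floor lies within the scatter) is the only measured step, and it cannot show any real change because compound 1 sits at the limit of > 48.1 uM in this assay, at which 1 of the 2 values shown sits. Within the data shown here, compound 2 thus stands as the only compound with an actual number among the two measured ones.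

Compound 3, `CCC1=C(O)c2c(oc(-c3ccc(O)c(O)c3)cc2=O)C(CC)(CC)C1=O`, changes the group on the same aromatic carbon: 3,4-dihydroxyphenyl in place of 2,4-dimethylphenyl on an aromatic carbon. Among the measured compounds shown here, no measured step involves a group like the entering one, so the expectation for compound 3 rests on the weak activity of compound 2 alone, and the step of a 1.1-fold higher number from compound 2 to compound 3 (0.04 log units; within the scatter) is estimated to be small. Compound 3 is therefore expected to give about 45 uM in this assay, within the range 15 uM to 150 uM.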

Compound 3, concentration for half-maximal effect: 10 uM
Estimate against measurement, compound 3: 4.5-fold (0.65 log units) above; the whole stated range lies above it.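

In this assay, within the data shown here, the group on the aromatic carbon next to the ring oxygen now shows a clear effect on the read-out: a 4.1-fold lower number from compound 2 to compound 3 (0.61 log units; beyond the scatter) is the first step that can be read as a real change, so this position is not indifferent to what it carries. The second step points the same way, with an at least 4.8-fold lower number from compound 1 to compound 3 (0.68 log units; beyond the scatter), and this gives only a minimum size for the change, since the entry for compound 1 is a limit and not a number: the limit of > 48.1 uM in this assay, at which 1 of the 3 values shown sits.

The compounds shown leave open whether the lower number comes from gaining the hydroxyl groups of the 3,4-dihydroxyphenyl group or from losing the methyl groups of the 2,4-dimethylphenyl group, and whether both hydroxyl groups are needed. As far as these compounds go, how a phenyl ring carrying an amine or a carboxylic acid at this position would behave in this assay also remains open.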